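Working notes: fluoro in place of chloro

A few compounds are considered here, and "the series" means these few. Any claim that something is new, unique, unknown or untested is made for them only; others in the source may bear on it.

compound 1 `C=CCNC(=S)N/N=C1\C(=O)Nc2ccccc21`: 26100 nM
compound 2 `CC(C)NC(=S)N/N=C1\C(=O)Nc2ccccc21`: 39300 nM
compound 3 `O=C1Nc2ccccc2/C1=N/NC(=S)Nc1ccc(Cl)cc1`: 13400 nM

All three values come from a functional assay on KB 3-1 cells (Homo sapiens) for cytotoxicity, read by MTT assay, with a stated time of 72 h; a lower number here means a stronger inhibitor, a higher number a weaker inhibitor. Compound 3 gives 13400 nM. The data show a 1.9-fold lower number from compound 1 to compound 3 (0.29 log units; within the scatter) and a 2.9-fold lower number from compound 2 to compound 3 (0.47 log units; beyond the scatter), so compound 3 stands apart from compound 2 only.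

The next compound is compound 4 `O=C1Nc2ccccc2/C1=N/NC(=S)Nc1ccc(F)cc1`: fluoro in place of chloro on an aromatic carbon. For the measured compounds named here, no measured step changes the halogen itself. Each one replaces the whole group on an amide-type nitrogen, and a 1.5-fold higher number from compound 1 to compound 2 (0.18 log units; within the scatter) also stays small. The largest of them, a 2.9-fold lower number from compound 2 to compound 3 (0.47 log units; beyond the scatter), is modest, so this smaller exchange is expected to give no step beyond the scatter in this assay.

The expected change is a 1.2-fold higher number from compound 3 to compound 4 (0.08 log units; within the scatter). Compound 4 is estimated at 16000 nM, with an expected range of 8000 nM to 31000 nM.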

Compound 4, half-maximal inhibitory concentration: 14200 nM
Estimate against measurement, compound 4: 1.1-fold (0.05 log units) above, and the stated range covers the measured number.
By their numbers in this assay, from the lowest: compounds 3, 4, 1 and 2 (each within the scatter of the next, the first and the last beyond it).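

Fluoro in place of chloro, para to a large group, is the only step in the series that changes the halogen itself, and in this assay it stays within the scatter (a 1.1-fold higher number from compound 3 to compound 4 (0.03 log units; within the scatter)). The 4-fluorophenyl compound repeats the picture seen with 4-chlorophenyl: the step from isopropyl lies beyond the scatter (a 2.8-fold lower number from compound 2 to compound 4 (0.44 log units; beyond the scatter)), while the step from allyl lies within it (a 1.8-fold lower number from compound 1 to compound 4 (0.26 log units; within the scatter)). No supporting measurement bears on these steps.

Open, from the compounds shown here alone, is whether an unsubstituted phenyl, or a methoxy or an amine at this place, would shift the number.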